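This account rests on a few compounds, and the source may have more. Where it says the series, first, only, none or still open, it means among the compounds named here.

Working notes on the series. Of the compounds shown here, three of a shared core have been measured in a functional assay on CHO cells for agonist activity at Free fatty acid receptor 1 (Homo sapiens), read by reporter gene assay; on this read-out higher numbers stand for larger maximal responses and lower numbers for smaller maximal responses. Compound 1 `O=C(O)CCc1ccc(NCc2cccc(Br)c2)cc1` carries a bromo group and gives in this assay a largest response of 120%; this is the second highest of the three numbers. Compound 2 `O=C(O)CCc1ccc(NCc2ccc(Cl)s2)cc1` is the nearest, with 143%, a number beyond the scatter above compound 1. Compound 3 `CN(C)Cc1ccc(CNc2ccc(CCC(=O)O)cc2)cc1` is the furthest, with 12%, beyond the scatter below compound 1. Within the data shown here, no step between two measured compounds that differ in one place is available, so the spread between compound 1 and compound 3 is only what their two values show.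

Compound 4 `CS(=O)(=O)Nc1cccc(CNc2ccc(CCC(=O)O)cc2)c1` has not yet been measured in this assay. It differs from compound 1 in one place: methanesulfonamido in place of bromo on an aromatic carbon, meta to a large group on the core. The entering group brings a hydrogen-bond donor and two acceptors where the bromo group had none. Among the measured compounds shown here, the only measured compound that carries a substituent with heteroatoms at this side of the core is compound 3, and its value of 12% is far below that of compound 1. On that basis a sizable drop is expected for compound 4, though not certainly to the level of compound 3. The expected step from compound 1 to compound 4 is a number 60 percentage points lower from compound 1 to compound 4 (beyond the scatter), downward and beyond the scatter. The estimate for compound 4 in this assay is 60%, with a range from 15% to 115%.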

Compound 4, largest response reached (reported as percent of maximum), in percent of the reference or control that the assay uses: 9%
Estimate against measurement, compound 4: 51 percentage points above; measured number outside the range, below it.
By their numbers in this assay, from the lowest: compounds 4 and 3 (each within the scatter of the next); then compound 1; then compound 2.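

Among these compounds, the one step that changes a single place falls on this aromatic carbon, meta to a large group: in this assay, methanesulfonamido in place of bromo gives a number 111 percentage points lower from compound 1 to compound 4 (beyond the scatter), a large step beyond the scatter. The largest response of this core therefore depends strongly on what stands at this one carbon, and the exchange of bromo for methanesulfonamido is not tolerated on this read-out. Nothing measured on either group bears on this step, and what in the change carries it stays unassigned.

The change adds heavy atoms, a hydrogen-bond donor and hydrogen-bond acceptors all at once, so the compounds shown leave open which of these goes with the drop; a methylsulfonyl group on the same carbon, without the nitrogen and the amide hydrogen, or an acetamido group, with the carbonyl in place of the sulfonyl part, would pull these apart. Also open, from the compounds shown here alone, is whether methanesulfonamido gives a similar step when placed on another carbon of the same ring.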